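Series notes: the step from compound 1 to compound 3

A few compounds are considered here, and "the series" means these few. Any claim that something is new, unique, unknown or untested is made for them only; others in the source may bear on it.

Compound 1 (`O=C1c2ccc(O)c(O)c2C(=O)N1Cc1ccc(F)cc1`) has no number in an ADME assay on HOS cells (Homo sapiens) for cytotoxicity (on this read-out lower numbers stand for stronger inhibition and higher numbers for weaker inhibition), and its entry reads ("not determined" (no result reported)). It therefore has no position on the scale, and any step starting from it cannot be sized from data. Among the measured compounds shown here, the only number belongs to compound 2 (`O=C1c2c(ccc(O)c2O)CN1Cc1cccc(F)c1`) at (8600 nM).

Compound 3 (`O=C1c2ccc(O)c(O)c2C(=O)N1Cc1cccc(Br)c1`) keeps the core of compound 1 and differs in a single group (3-bromophenyl in place of 4-fluorophenyl on a saturated chain carbon bound to an amide-type nitrogen in a ring). This places 3-bromophenyl in place of 4-fluorophenyl on a saturated chain carbon bound to an amide-type nitrogen in a ring. Apart from fluorine leaving and bromine entering, the counted features of the two groups match.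

With no starting number, no direction can be argued, and no step beyond the scatter is expected in this assay for this change. For the measured compounds named here, the expectation therefore leans on the single measured value, that of compound 2 (8600 nM), and the range is kept wide. The expected value for compound 3 is 9000 nM in this read-out (estimated range 3000 nM to 30000 nM).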

Compound 3, half-maximal inhibitory concentration: 11400 nM
Compound 3: middle estimate off by 1.3-fold (0.10 log units), on the low side; the range from low to high includes it.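

In this assay compound 3 gives 11400 nM while compound 1 has no number, so no step can be read between them. The compounds shown leave open how 3-bromophenyl compares with 4-fluorophenyl on the shared core in this read-out. No available evidence bears on this result.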